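A few compounds are considered here, and "the series" means these few. Any claim that something is new, unique, unknown or untested is made for them only; others in the source may bear on it.

Of the compounds shown here, three have so far been tested in a functional assay on Caco-2 cells (Homo sapiens) for inhibition, read by CCK-8 assay, with a stated time of 72 h; on this read-out higher numbers stand for weaker inhibition and lower numbers for stronger inhibition. Compound 1, `CC12CC34CC[C@H](O)[C@@](C)(CCCO)C3C(CC1C4)O2`, gives 37500 nM. Compound 2, `CC12CC34CC[C@H](OC(=O)c5ccc(NCc6cc(O)ccc6O)cc5)[C@@](C)(CCCOC(=O)c5ccc(NCc6cc(O)ccc6O)cc5)C3C(CC1C4)O2`, gives 7000 nM. Compound 3, `O=C(O)c1ccc(NCc2cc(O)ccc2O)cc1`, gives 49800 nM, the highest of the three numbers; its gap to compound 1 lies within the usual scatter of repeated measurements, while compound 2 reaches a lower number than compound 3 by a gap beyond that scatter, so compound 2 inhibits more strongly. Compound 4, `COC(=O)c1ccc(NCc2cc(O)ccc2O)cc1`, has not yet been measured. It differs from compound 3 in one place: methyl in place of hydrogen on an oxygen next to a carbonyl group. Within the data shown here, no measured pair shows this same change, so its effect here is unknown. The step in this assay is expected to be a 1.7-fold lower number from compound 3 to compound 4 (0.22 log units; within the scatter), a small move toward stronger inhibition, close to the scatter. Compound 4 is estimated at 30000 nM, between 10000 nM and 90000 nM.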

Compound 4, half-maximal inhibitory concentration: 15100 nM
Compound 4: middle estimate off by 2.0-fold (0.30 log units), on the high side; the measured number falls inside the stated range.
By their numbers in this assay, from the lowest: compound 2; then compound 4; then compounds 1 and 3 (each within the scatter of the next).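

Replacing hydrogen with methyl on this oxygen turns carboxy into methoxycarbonyl and gives a 3.3-fold lower number from compound 3 to compound 4 (0.52 log units; beyond the scatter) in this assay. Among these compounds, this is the first measured pair that differs in one place, and it shows that the read-out responds to a change at this oxygen, here toward stronger inhibition. Nothing measured here gives a reason for this step. As far as these compounds go, it remains open whether an ethyl ester or a longer chain on this oxygen would lower the number further, and how an amide in the same place would compare.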